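This account rests on a few compounds, and the source may have more. Where it says the series, first, only, none or still open, it means among the compounds named here.

Measured so far:
- compound 1, `CN1CCC(c2n[nH]c3ccc(S(=O)(=O)c4ccc5ccccc5c4)cc23)CC1`, gives 100%
- compound 2, `CN1CCC(c2n[nH]c3ccc(S(=O)(=O)c4cccc(Cl)c4)cc23)CC1`, gives 95%

Both values come from a functional assay on HeLa cells for antagonist activity at 5-hydroxytryptamine receptor 6 (Homo sapiens), read by cAMP accumulation; a lower number here means a smaller maximal response, a higher number a larger maximal response. Compound 2 has the lower of the two numbers shown, but its nearest neighbour is compound 1, whose value lies within the scatter of that of compound 2, so the two cannot be told apart on this assay. Among the compounds with values here, no step between two measured compounds that differ in one place is available.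

The next compound, compound 3, `CC(C)c1ccc(S(=O)(=O)c2ccc3[nH]nc(C4CCN(C)CC4)c3c2)cc1`, differs from compound 2 in one place: 4-isopropylphenyl in place of 3-chlorophenyl on a sulfonyl sulfur. Within the data shown here, with the two measured values so close and no comparable step known, there is no ground for expecting a shift beyond the scatter, in either direction. The estimated step from compound 2 to compound 3 is therefore a number 2 percentage points higher from compound 2 to compound 3 (within the scatter), expected to stay within the scatter. For compound 3 in this assay the expected value is 97%, with a range from 85% to 105%.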

Compound 3, largest response reached (reported as Imax), in percent of the reference or control that the assay uses: 100%
For compound 3 the middle estimate is 3 percentage points below the measured one, within the range that was stated.
By their numbers in this assay, from the lowest: compounds 2, 1 and 3 (each within the scatter of the next).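

In this assay, within the data shown here, 4-isopropylphenyl in place of 3-chlorophenyl on a sulfonyl sulfur gives a number 5 percentage points higher from compound 2 to compound 3 (within the scatter), the only step yet available between compounds that differ in one place. This change replaces a chlorine-bearing phenyl group with a purely carbon group and alters the name and printed position of the substituent, yet the maximal response does not separate the two compounds. At this position, therefore, the two aromatic groups cannot be told apart on this read-out, and nothing measured here offers a reason for that result.

The compounds shown leave open whether a sulfonyl substituent without a carbon-only aromatic ring, such as one carrying an amine or a carboxylic acid, would give a step beyond the scatter. A longer chain in place of the isopropyl group also remains an open case.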